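Adding a Methoxy Group Beside the Anilino Nitrogen

A few compounds are considered here, and "the series" means these few. Any claim that something is new, unique, unknown or untested is made for them only; others in the source may bear on it.

Compound 1 `FC(F)(F)c1ccc(CSc2nc(N3CCCCC3)c3ccccc3n2)cc1` carries a piperidin-1-yl group on an aromatic carbon of the shared core. In a functional assay on HGC-27 cells (Homo sapiens) for cytotoxicity, read by MTT assay, with a stated time of 72 h (a higher number here means a weaker inhibitor, a lower number a stronger inhibitor), compound 1 gives > 50000 nM, which is a limit of the assay rather than a number. Compound 2 `FC(F)(F)c1ccc(CSc2nc(Nc3ccccc3)c3ccccc3n2)cc1` has an anilino group in that position, and in this assay compound 2 gives 26400 nM. That is an at least 1.8-fold lower number from compound 1 to compound 2 (0.27 log units; that floor lies within the scatter). Among the two values shown, compound 2 therefore holds the only real number, the other being (the limit of > 50000 nM in this assay, at which 1 of the 2 values shown sits).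

Compound 3 `COc1ccccc1Nc1nc(SCc2ccc(C(F)(F)F)cc2)nc2ccccc12` differs from compound 2 by methoxy in place of hydrogen on an aromatic carbon. For the measured compounds named here, the one measured step, from compound 1 to compound 2, concerns a swap of the whole group on the core, not a substituent on the anilino ring, so no measured step bears directly on this change. With no guidance from the data, the expectation is a step no larger than the scatter, in either direction. Compound 3 is therefore expected to give 25000 nM, with a range from 8000 nM to 70000 nM. The expected step is a 1.1-fold lower number from compound 2 to compound 3 (0.02 log units; within the scatter), which lies within the scatter.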

Compound 3, half-maximal inhibitory concentration: > 50000 nM
Compound 3: a limit, no number; the forecaster's own chance of this, stated with the estimate: 30%; middle value at least 2.0-fold (0.30 log units) away from the limit.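

In this assay, the change from anilino to (2-methoxyphenyl)amino is the first one shown on the anilino ring itself, rather than a swap of the whole group on the shared core, and it gives an at least 1.8-fold higher number from compound 2 to compound 3 (0.27 log units; that floor lies within the scatter). A real loss is not established, as the floor of that step lies within the scatter, but nothing here points to a gain from methoxy on an aromatic carbon ortho to a large group. Compound 1 and compound 3 both stand at a limit of the assay and not at a number, so the step between them cannot be read, and the one real number still belongs to compound 2: the limit of > 50000 nM in this assay, at which 2 of the 3 values shown sit.

On these data alone, it remains open whether a fluorine atom or a hydroxy group in this same place on the ring would keep a readable number in this assay. Also open, as far as these compounds go, is whether methoxy would behave the same way at another carbon of the anilino ring.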